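Compound 4: nitro in place of hydroxy

The compounds below may be only part of what the source reports. "The series", "measured", "known", "first", "only" and "open" are said of these compounds alone.

Three compounds of the series have numbers in an assay on cell membranes for displacement of a labelled ligand from Neuronal acetylcholine receptor; alpha4/beta2 (Rattus norvegicus); on this read-out higher numbers stand for weaker inhibition and lower numbers for stronger inhibition. Compound 1 `COc1ccc(Nc2ccc(N3CC4CC(C3)N4)nn2)cc1` gives 578 nM. Compound 2 `Oc1ccc(Nc2cncc(N3CC4CC(C3)N4)c2)cc1` gives 0.342 nM. Compound 3 `Clc1cccc(Nc2cncc(N3CC4CC(C3)N4)c2)c1` gives 0.124 nM. Compound 2 therefore stands second highest of the three in this assay, its nearest neighbour being compound 3 and its furthest compound 1, whose number lies far above both.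

Compound 4 `O=[N+]([O-])c1ccc(Nc2cncc(N3CC4CC(C3)N4)c2)cc1` is not yet measured. It differs from compound 2 in one place: nitro in place of hydroxy on an aromatic carbon.

Going by the values given here, one measured step bears on this change, though loosely: a 2.8-fold lower number from compound 2 to compound 3 (0.44 log units; beyond the scatter), which exchanged the whole substituted phenyl rather than a single group on it. Since both the hydroxy-bearing compound 2 and the chloro-bearing compound 3 give very low numbers in this assay, a change confined to one group on that ring is expected to move the number little, most likely within the scatter, with a small shift in either direction possible.

For compound 4 the estimate in this assay is 0.35 nM, with a range from 0.09 nM to 1.4 nM. This corresponds to an expected step of a 1.0-fold higher number from compound 2 to compound 4 (0.01 log units; within the scatter).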

Compound 4, inhibition constant: 0.0225 nM
Estimate against measurement, compound 4: 16-fold (1.19 log units) above, and the stated range ends above it.
By their numbers in this assay, from the lowest: compound 4; then compound 3; then compound 2; then compound 1.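

In this assay, exchanging hydroxy for nitro on this aromatic carbon, para to a large group, gives a 15-fold lower number from compound 2 to compound 4 (1.18 log units; beyond the scatter). This position is therefore more sensitive than compound 2 and compound 3 alone could show, as a change of one group on the ring moves the number well beyond the scatter. A hydrogen-bond donor on this carbon is also not required for a very low number, since compound 4 has none there and gives 0.0225 nM; no measurement at hand bears on what lies behind the step.

Open, as far as these compounds go, is whether an amine or a carboxylic acid on the same carbon would stay close to compound 2 or approach compound 4. Compound 3 and compound 4 differ in more than one place, so chloro and nitro remain uncompared on a single carbon.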